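Swapping chloro for methyl on the aryl group

This account rests on a few compounds, and the source may have more. Where it says the series, first, only, none or still open, it means among the compounds named here.

Compound 1 `O=C1C=C(N2CCN(c3ccccc3Cl)CC2)C(=O)c2ccccc21`: 11300 nM
Compound 2 `O=C1C=C(N2CCN(c3ccccc3Cl)CC2)C(=O)c2c(O)cccc21`: 7200 nM

In a functional assay on HeLa cells (Homo sapiens) for antiproliferative activity, read by MTT assay, with a stated time of 72 h (on this read-out higher numbers stand for weaker inhibition and lower numbers for stronger inhibition), compound 2 gives 7200 nM. Going by the values given here, this is the lower of only two numbers, but the gap to compound 1 lies within the scatter, so the two cannot really be ranked.

The next compound, compound 3 `Cc1ccccc1N1CCN(C2=CC(=O)c3cccc(O)c3C2=O)CC1`, keeps the rest of compound 2 and carries methyl in place of chloro on an aromatic carbon. The change lies on an aromatic carbon of a six-membered aromatic ring of carbon only, ortho to a large group.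

Among the compounds with values here, the only measured step is a 1.6-fold lower number from compound 1 to compound 2 (0.20 log units; within the scatter). It concerns a hydroxy in place of hydrogen, a different change, and it bears on this one only indirectly. Within the data shown here, no measurement yet tests a change of the chloro group, so no direction can be argued and no step beyond the scatter is expected. The expectation takes compound 2 at 7200 nM as its starting point.

The estimated step is a 1.0-fold higher number from compound 2 to compound 3 (0.02 log units; within the scatter).

For compound 3 the expected value is 7500 nM.

The estimated range for compound 3 runs from 3000 nM to 19000 nM.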

Compound 3, half-maximal inhibitory concentration: 7200 nM
For compound 3 the middle estimate is 1.0-fold (0.02 log units) above the measured one; low and high end bracket the measured number.
By their numbers in this assay, from the lowest: compounds 2, 3 and 1 (each within the scatter of the next).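

In this assay, the 2-chlorophenyl group of compound 2 becomes 2-methylphenyl in compound 3, and the swap gives no change at the digits printed from compound 2 to compound 3 (within the scatter) on this read-out. Going by these compounds alone, the earlier step changed a different part of the molecule, so this is the first result that tests this aromatic carbon, ortho to a large group. It shows that here, in the presence of the hydroxy group of compound 2, chloro and methyl, each a single heavy atom with no hydrogen-bond donors or acceptors, cannot be told apart in this assay. No measurement available here explains why the two groups read alike.

One pair of groups at one place cannot show whether this position tolerates change in general, and a different group here, such as methoxy, an amine or a carboxylic acid, might or might not move the number beyond the scatter. From the compounds shown here alone, it also remains open whether the same swap would read the same way on compound 1, which lacks the hydroxy group.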